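Lengthening the Amine Chain of Compound 1

This account rests on a few compounds, and the source may have more. Where it says the series, first, only, none or still open, it means among the compounds named here.

For the measured compounds named here, compound 1 `CN(C)CCNc1nc(-c2ccc(NC(=O)Nc3ccc(F)cc3)cc2)nc2c(Cl)c(Cl)sc12` is one of two compounds measured in a functional assay on MKN-45 cells (Homo sapiens) for cytotoxicity, read by MTT assay, with a stated time of 72 h; on this read-out higher numbers stand for weaker inhibition and lower numbers for stronger inhibition. In this assay compound 1 gives 1350 nM, the higher of the two numbers, while compound 2 `CN(C)CCNc1nc(-c2ccc(NC(=O)Nc3ccccc3Cl)cc2)nc2c(Cl)c(Cl)sc12` gives 1170 nM in this assay. The step of a 1.2-fold lower number from compound 1 to compound 2 (0.06 log units; within the scatter) lies within the scatter, so the two compounds cannot be separated on these numbers, and that single step concerns the aryl group on the urea, not the amine-bearing chain.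

Compound 3 `CCN(CC)CCCNc1nc(-c2ccc(NC(=O)Nc3ccc(F)cc3)cc2)nc2c(Cl)c(Cl)sc12` differs from compound 1 at that chain: (diethylamino)methyl in place of dimethylamino on a saturated chain carbon, two bonds along the chain from a nitrogen on an aromatic ring. Going by the values given here, no measured step touches this part of the molecule; the only step available concerns a different position and was itself within the scatter. Among the compounds with values here, there is thus no direct precedent for the change, and the numbers give no ground to expect a move in either direction. For compound 3 one therefore expects no step beyond the scatter in this assay, no change at the digits printed from compound 1 to compound 3 (within the scatter), with a wide range to reflect the missing precedent. Compound 3 is estimated at 1350 nM in this assay, between 450 nM and 4000 nM.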

Compound 3, half-maximal inhibitory concentration: 1700 nM
Compound 3: middle estimate off by 1.3-fold (0.10 log units), on the low side, and the stated range covers the measured number.
By their numbers in this assay, from the lowest: compounds 2, 1 and 3 (each within the scatter of the next).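

With compound 3, the amine-bearing chain has a measured step of its own: exchanging 2-(dimethylamino)ethyl for 3-(diethylamino)propyl gives, in this assay, a 1.3-fold higher number from compound 1 to compound 3 (0.10 log units; within the scatter). Compound 1 and compound 3 therefore cannot be separated on these numbers, so in this one pair the position accepts the added carbon atoms without a step beyond the scatter, as was also the case for the earlier change to the aryl group on the urea. No measurement here offers an explanation for this result, whether from the properties of the chain or from anything else.

This single step changes the chain length and the groups on the end nitrogen together, so it cannot be divided between them without a 3-(dimethylamino)propyl or a 2-(diethylamino)ethyl chain for comparison. Also open, as far as these compounds go, is what a chain ending in a morpholine, a primary amine or a carboxylic acid would give, and whether the 3-(diethylamino)propyl chain would behave the same way alongside the 2-chlorophenyl urea of compound 2.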